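Predicting Compound 4 from Two Matched Structural Changes

The source may hold more compounds than are shown below. What is called first, only, known or untested is meant among the compounds shown, and "the series" means these compounds.

The measured compounds and their values:
- compound 1, `COC(=O)/C=C/c1cccc(N(Cc2ccc(/C=C/c3ccc(F)cc3)cc2)C(=O)C(C)C)c1`, gives 120 nM in an assay on isolated protein with Bile acid receptor (Homo sapiens) as the target; a lower number here means that less compound is needed, a higher number that more compound is needed for the effect
- compound 2, `COC(=O)/C=C/c1cccc(N(Cc2ccc(-c3cc(Cl)ccc3OC)cc2)C(=O)C(C)C)c1`, gives 226 nM in this assay
- compound 3, `COC(=O)/C=C/c1cccc(N(Cc2ccc(/C=C/c3ccc(F)cc3)cc2)C(=O)C2CCCCC2)c1`, gives 185 nM in this assay

Compound 2 is related to compound 1 by a single change, (5-chloro-2-methoxyphenyl in place of 2-(4-fluorophenyl)ethenyl on an aromatic carbon). That change produced a 1.9-fold higher number from compound 1 to compound 2 (0.27 log units; within the scatter). Compound 3 is also a single change away from compound 1, namely (cyclohexyl in place of isopropyl on a carbonyl carbon), and this gave a 1.5-fold higher number from compound 1 to compound 3 (0.19 log units; within the scatter). Compounds 2 and 3 are not directly compared here; their two values sit within the usual scatter of each other.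

Compound 4, `COC(=O)/C=C/c1cccc(N(Cc2ccc(-c3cc(Cl)ccc3OC)cc2)C(=O)C2CCCCC2)c1`, has not yet been measured. It differs from compound 3 by 5-chloro-2-methoxyphenyl in place of 2-(4-fluorophenyl)ethenyl on an aromatic carbon. This is the same change already seen between compound 1 and compound 2, made here on the core of compound 3 rather than on the core of compound 1; the difference between those two cores is the one described above as cyclohexyl in place of isopropyl on a carbonyl carbon.

Going by the values given here, since the change from compound 1 to compound 2 moved the number only modestly, the expectation for compound 4 rests on that earlier result: the step from compound 3 to compound 4 is estimated at a 1.9-fold higher number from compound 3 to compound 4 (0.28 log units; within the scatter), alongside a 1.9-fold higher number from compound 1 to compound 2 (0.27 log units; within the scatter), because a 1.9-fold higher number from compound 1 to compound 2 (0.27 log units; within the scatter) is the only direct evidence for this change. Compound 4 is therefore expected to give about 350 nM in this assay, with the likely range estimated from 150 nM to 800 nM.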

Compound 4, half-maximal effective concentration: 233 nM
Estimate against measurement, compound 4: 1.5-fold (0.18 log units) above; the range from low to high includes it.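

In this assay, 5-chloro-2-methoxyphenyl in place of 2-(4-fluorophenyl)ethenyl on the core of compound 3 gave a 1.3-fold higher number from compound 3 to compound 4 (0.10 log units; within the scatter), and this step does not differ from the earlier one on the core of compound 1: the same change on two cores in this assay, a 1.9-fold higher number (0.27 log units; within the scatter) from compound 1 to compound 2 and a 1.3-fold higher number (0.10 log units; within the scatter) from compound 3 to compound 4, 1.5-fold (0.17 log units) apart, within the scatter of two such steps. Read the other way round, cyclohexyl in place of isopropyl on the core of compound 2 gave a 1.0-fold higher number from compound 2 to compound 4 (0.01 log units; within the scatter), and this change also carried from one core to the other without a difference beyond the scatter: the same change on two cores in this assay, a 1.5-fold higher number (0.19 log units; within the scatter) from compound 1 to compound 3 and a 1.0-fold higher number (0.01 log units; within the scatter) from compound 2 to compound 4, 1.5-fold (0.17 log units) apart, within the scatter of two such steps. Across these four compounds, neither change shows any dependence on the core that carries it, but every step here lies within the scatter, so the agreement shows only that neither change moved the number measurably on either core, and it does not show that a change with a larger step would carry over in the same way.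

The compounds shown leave open how the number would respond if the methyl ester gave way to a carboxylic acid, or if the isopropyl or cyclohexyl on the carbonyl gave way to a longer chain. They also leave open whether changes with steps beyond the scatter would carry between these cores as these two do.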